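Dropping the Methoxy From a Weak Chaperone Inhibitor

A few compounds are considered here, and "the series" means these few. Any claim that something is new, unique, unknown or untested is made for them only; others in the source may bear on it.

Compound 1 `COc1ccc(Br)cc1C(=O)Nc1ccc(Sc2nc3ccccc3s2)cc1` is the starting point. In an assay for inhibition of HSP60/HSP10 (Homo sapiens), with a stated time of 60 min (a higher number here means a weaker inhibitor, a lower number a stronger inhibitor), compound 1 gives > 100000 nM, which is a limit of the assay rather than a number. Its companion compound 2 `O=C(Nc1ccc(Sc2nc3ccccc3s2)c(Cl)c1)c1cc(Br)ccc1O` was measured in the same way. Compound 2 gives > 100000 nM in this assay, again only a limit. Both values therefore sit at the limit of > 100000 nM in this assay, at which 2 of the 2 values shown sit, and compound 1 stands there alongside everything else measured, with no number setting it higher or lower.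

Compound 3 `O=C(Nc1ccc(Sc2nc3ccccc3s2)cc1)c1cccc(Br)c1` has not yet been measured. It differs from compound 1 in one place: hydrogen in place of methoxy on an aromatic carbon. Going by the values given here, no measured pair shows what this change does here, and nothing points to a shift beyond the scatter. The expected step is a step that the limit leaves unreadable from compound 1 to compound 3. Compound 3 is thus expected to give about 150000 nM in this assay, most likely again as a limit, within a range from 30000 nM to 1000000 nM.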

Compound 3, half-maximal inhibitory concentration: > 100000 nM
Compound 3: a limit, no number (the forecaster's own chance of this, stated with the estimate: 75%); the middle value is on the limit's open side.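

No step can be read from compound 1 to compound 3, because each gives only a limit and no number: the limit of > 100000 nM in this assay, at which 3 of the 3 values shown sit.

The compounds shown leave open whether hydrogen in place of methoxy changes the inhibition at all, and which change to the shared core would give a readable number.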